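The source may report more compounds than this note shows. Statements on the series, on what has been measured and on what is new or still open speak of the compounds shown alone.

Measured so far:
- compound 1, `CCCCN(c1nc2c(C(=O)O)cccc2o1)[C@H](C)c1ccc(-c2ccccc2-c2nnn[nH]2)cc1`: 429 ng.h/mL
- compound 2, `CCCCN(c1nc2c(NS(C)(=O)=O)cccc2o1)[C@H](C)c1ccc(-c2ccccc2-c2nnn[nH]2)cc1`: 73.8 ng.h/mL
- compound 3, `CCCCN(c1nc2c(C(=O)NC)cccc2o1)[C@H](C)c1ccc(-c2ccccc2-c2nnn[nH]2)cc1`: 25.7 ng.h/mL

These three compounds share one core and differ only in the group on an aromatic carbon of that core. In an ADME assay on the whole organism (Macaca fascicularis) for pharmacokinetics, read by LC-MS, using cassette dosing, at a dose of 1 mg/kg by the oral route (a higher number here means more compound in the circulation at the dose given, a lower number less compound in the circulation), compound 3 stands lowest of the three. The step of a 2.9-fold lower number from compound 2 to compound 3 (0.46 log units; beyond the scatter) separates it from its nearest neighbour, and the step of a 17-fold lower number from compound 1 to compound 3 (1.22 log units; beyond the scatter) from the furthest. The third measured step, a 5.8-fold lower number from compound 1 to compound 2 (0.76 log units; beyond the scatter), shows that the carboxy group of compound 1 gives the highest number of the set.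

Compound 4, `CCCCN(c1nc2c(CO)cccc2o1)[C@H](C)c1ccc(-c2ccccc2-c2nnn[nH]2)cc1`, has not yet been measured. It differs from compound 3 in one place: hydroxymethyl in place of methylcarbamoyl on an aromatic carbon. Within the data shown here, no measured step involves a hydroxymethyl group, so the change is new to this set. What the measured steps do show is that every group other than carboxy sits well below compound 1, and that the two neutral groups of compounds 2 and 3 lie within a modest distance of each other. Compound 4 carries a neutral group that keeps a hydrogen-bond donor and acceptor, like compound 3, so a step of no more than modest size from compound 3 is expected, with the direction uncertain. The estimate for compound 4 is therefore 40 ng.h/mL, in a range from 10 ng.h/mL to 150 ng.h/mL, which corresponds to an expected step of a 1.6-fold higher number from compound 3 to compound 4 (0.19 log units; within the scatter).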

Compound 4, area under the concentration-time curve: 20 ng.h/mL
Compound 4: the middle estimate sits 2.0-fold (0.30 log units) above what was measured; low and high end bracket the measured number.
By their numbers in this assay, from the lowest: compounds 4 and 3 (each within the scatter of the next); then compound 2; then compound 1.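

In this assay, hydroxymethyl in place of methylcarbamoyl on this aromatic carbon gives a 1.3-fold lower number from compound 3 to compound 4 (0.11 log units; within the scatter), so removing the carbonyl and shortening the group, while keeping the same hydrogen-bond donor and acceptor counts and no net charge, produces no readable change. Hydroxymethyl also falls with the other non-carboxy groups, well under the carboxy compound, at a 21-fold lower number from compound 1 to compound 4 (1.33 log units; beyond the scatter), and the gap to the methanesulfonamido compound, a 3.7-fold lower number from compound 2 to compound 4 (0.57 log units; beyond the scatter), is as clear as the one already seen for methylcarbamoyl; across these four compounds, the carboxy group alone reaches the highest number, and compound 2 stands apart from compounds 3 and 4 by a modest step. Nothing available here bears on the reason for these differences.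

The four compounds leave open whether an amine, an ester or a longer chain ending in a hydroxy group on this carbon would stay near compounds 3 and 4 or come closer to compound 1. A single area under the curve also leaves open whether these gaps arise during uptake from the gut or during removal from the circulation.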